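The compounds below may be only part of what the source reports. "The series", "measured", "known", "first", "only" and "open" are said of these compounds alone.

Measured compounds:
compound 1 `CSc1nccc2c1ncn2C1O[C@H](CO)[C@@H](O)[C@H]1O` — 24%
compound 2 `Sc1[nH]ccc2ncnc1-2` — 26%
compound 3 `OC[C@H]1O[C@@H](n2cnc3c(S)nccc32)C[C@@H]1O` — 10%

In a functional assay (Homo sapiens) for inhibition of Nucleic Acid, tested at 100 uM (a lower number here means less inhibition, a higher number more inhibition at the concentration tested (going by the name of the read-out)), compound 2 gives 26%, the highest of the three numbers. Compound 1 gives 24%, a number within the scatter of compound 2, so no order between these two is claimed. Compound 3 gives 10%, a number beyond the scatter and lower than that of compound 2. Compound 4 `CNc1[nH]ccc2ncnc1-2` has not yet been measured in this assay; it differs from compound 2 in one place: methylamino in place of sulfanyl on an aromatic carbon. Among the measured compounds shown here, no measured pair shows this change, so nothing about its effect is known from the numbers at hand. The step of a number 4 percentage points lower from compound 2 to compound 4 (within the scatter) is expected to stay within the scatter, with no clear direction. Compound 4 is estimated at 22%, within a range from 5% to 45%.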

Compound 4, a percentage reported as inhibition, at one concentration (the size of the read-out at that concentration, not a potency): 18%
For compound 4 the middle estimate is 4 percentage points above the measured one; measured number inside the range.
By their numbers in this assay, from the lowest: compounds 3, 4, 1 and 2 (each within the scatter of the next, the first and the last beyond it).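

In this assay, methylamino in place of sulfanyl on an aromatic carbon, next to the ring nitrogen, gives a number 8 percentage points lower from compound 2 to compound 4 (within the scatter). Sulfur at this position is therefore not needed for a reading of this size, which the earlier compounds, all carrying sulfur, could not show. No measurement at hand accounts for the step.

As far as these compounds go, whether a primary amine, a longer chain on the nitrogen or a carboxylic acid at this position would reach beyond the scatter stays open. Also open, from the compounds shown here alone, is whether the same exchange would read alike on compound 3.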